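A few compounds are considered here, and "the series" means these few. Any claim that something is new, unique, unknown or untested is made for them only; others in the source may bear on it.

Measured compounds in a functional assay on HCT-116 cells (Homo sapiens) for antiproliferative activity, read by MTT assay, with a stated time of 72 h; on this read-out lower numbers stand for stronger inhibition and higher numbers for weaker inhibition:
compound 1, `Cc1ccc(S(=O)(=O)N(C)c2ccc3[nH]c(-c4n[nH]c5ccccc45)cc3n2)cc1`, gives 13300 nM;
compound 2, `COc1ccc(S(=O)(=O)N(C)c2ccc3[nH]c(-c4n[nH]c5ccccc45)cc3n2)cc1`, gives 22400 nM;
compound 3, `CN(c1ccc2[nH]c(-c3n[nH]c4ccccc34)cc2n1)S(=O)(=O)c1cccc([N+](=O)[O-])c1`, gives 13600 nM.

Compound 3 sits among these three with both of its neighbours inside the usual scatter: a 1.0-fold higher number from compound 1 to compound 3 (0.01 log units; within the scatter) and a 1.6-fold lower number from compound 2 to compound 3 (0.22 log units; within the scatter). Compound 4, `CN(c1ccc2[nH]c(-c3n[nH]c4ccccc34)cc2n1)S(=O)(=O)c1ccc(OC(F)(F)F)cc1`, differs from compound 3 in one place: 4-(trifluoromethoxy)phenyl in place of 3-nitrophenyl on a sulfonyl sulfur. The two earlier swaps of the aryl group on the sulfonyl sulfur, from compound 1 to compound 3 and from compound 2 to compound 3, moved the numbers in this assay by no more than the scatter, and a third swap at the same place is expected to behave alike. For compound 4 the expected step in this assay is a 1.0-fold higher number from compound 3 to compound 4 (0.01 log units; within the scatter). Compound 4 is therefore estimated at 14000 nM, within 6000 nM to 35000 nM.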

Compound 4, half-maximal inhibitory concentration: 6040 nM
Compound 4: the middle estimate sits 2.3-fold (0.37 log units) above what was measured; the range from low to high includes it.
By their numbers in this assay, from the lowest: compound 4; then compounds 1, 3 and 2 (each within the scatter of the next).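

In this assay, the aryl group on the sulfonyl sulfur proves able to move the number beyond the scatter: 4-(trifluoromethoxy)phenyl brings a 2.3-fold lower number from compound 3 to compound 4 (0.35 log units; beyond the scatter) and a 2.2-fold lower number from compound 1 to compound 4 (0.34 log units; beyond the scatter) and also a 3.7-fold lower number from compound 2 to compound 4 (0.57 log units; beyond the scatter). Going by these compounds alone, the earlier swaps at this position stayed within the scatter, so only this change shows that the position is not indifferent to the group it carries. Nothing available here explains the shift.

On these data alone, whether an amine or a carboxylic acid on the aryl ring would shift the number further stays open. So does the effect of a longer chain in place of that ring.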